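Butyl for fluorophenyl on the shared core

The source may report more compounds than this note shows. Statements on the series, on what has been measured and on what is new or still open speak of the compounds shown alone.

Compound 2 `Fc1ccccc1-c1nc(Cc2c[nH]c3ccccc23)no1` stands at the limit of a functional assay on cells (Splenocyte, Mus musculus, strain BALB/c) for inhibition, read by scintillation counting and thymidine incorporation, with stated times of 48 h and 8 h; on this read-out lower numbers stand for stronger inhibition and higher numbers for weaker inhibition; in this assay compound 2 gives > 50000 nM, which is a limit of the assay and not a number. Its methoxy counterpart compound 1 `COc1ccccc1-c1nc(Cc2c[nH]c3ccccc23)no1` gives 16700 nM in this assay. Going by the values given here, the step of an at least 2.9-fold higher number from compound 1 to compound 2 (0.47 log units; beyond the scatter) is the only measured step in the set, and compound 2 sits at the limit of > 50000 nM in this assay, at which 1 of the 3 values shown sits. Compound 3 `Fc1ccc(-c2nc(Cc3c[nH]c4ccccc34)no2)c(C(F)(F)F)c1`, which carries fluoro and trifluoromethyl on its phenyl, gives 15700 nM in this assay.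

Compound 4 `CCCCc1nc(Cc2c[nH]c3ccccc23)no1` differs from compound 2 by butyl in place of 2-fluorophenyl on an aromatic carbon. Among the compounds with values here, no measured step exchanges the whole aromatic group for a chain: the one step known, methoxy to fluoro, concerns a substituent on that ring and does not bear on removing it. Compounds 1 and 3 show that a phenyl with other substituents can give a number in this assay, but nothing shows what a butyl group does there. The starting point being a limit, any expectation for compound 4 is anchored loosely. Compound 4 is expected to give about 50000 nM, within 15000 nM to 150000 nM, in this assay. The step of a number no higher from compound 2 to compound 4 (the limit leaves the size open) expected here is thus no clear change beyond the scatter, with a fair chance that compound 4 again reports only a limit.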

Compound 4, half-maximal inhibitory concentration: > 50000 nM
Compound 4 ended at the assay's limit; the forecaster's own chance of this, stated with the estimate: 55%; the middle value lies on the limit itself.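

In this assay, compound 2 and compound 4 each report only a limit of the assay and not a number, so no step between them can be read: the limit of > 50000 nM in this assay, at which 2 of the 4 values shown sit.

The compounds shown leave open whether butyl in place of 2-fluorophenyl on the shared core changes inhibition at all in this assay.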